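A Methoxy Added to the More Active Compound

This account rests on a few compounds, and the source may have more. Where it says the series, first, only, none or still open, it means among the compounds named here.

Compound 1 (`COc1cc(C(=O)c2cccc3ncccc23)cc(OC)c1OC`): 2800 nM 
Compound 2 (`COc1cc(C(=O)c2ccc3ncccc3c2)cc(OC)c1OC`): 24.6 nM 

These two values come from a functional assay on HT-29 cells (Homo sapiens) for antiproliferative activity, with a stated time of 72 h (on this read-out lower numbers stand for stronger inhibition and higher numbers for weaker inhibition), a test of how well each compound holds back the growth of cancer cells. Compound 2 has the lower number of the pair, and its gap to compound 1 lies well beyond the usual scatter of repeated measurements.

Compound 3 (`COc1ccc2cc(C(=O)c3cc(OC)c(OC)c(OC)c3)ccc2n1`) has not been measured yet. It differs from compound 2 in one place (methoxy in place of hydrogen on an aromatic carbon), with a methoxy in place of hydrogen on an aromatic carbon, next to the ring nitrogen.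

Among the measured compounds shown here, no measured pair shows what this particular change does, so any forecast here has to stay cautious. A modest shift toward weaker inhibition seems the likeliest outcome in this assay, though a result within the scatter of compound 2 would be no surprise. The expected change is a 1.6-fold higher number from compound 2 to compound 3 (0.21 log units; within the scatter), a small step next to the wide gap between the two measured compounds. Compound 3 is estimated at 40 nM, with an expected range from 10 nM to 200 nM.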

Compound 3, half-maximal inhibitory concentration: 206 nM
The estimate for compound 3 lay 5.2-fold (0.71 log units) below the measured number; measured number outside the range, above it.
By their numbers in this assay, from the lowest: compound 2; then compound 3; then compound 1.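

In this assay, a methoxy in place of hydrogen on an aromatic carbon next to the ring nitrogen gives an 8.4-fold higher number from compound 2 to compound 3 (0.92 log units; beyond the scatter). Among the compounds shown here, this is the first direct reading of this position, and it shows that the position is sensitive: adding just this one group to compound 2 produces a real weakening of inhibition. The shift lies beyond the usual scatter of repeated measurements. Nothing available here explains why the number rises, so the step stands as an observation without a known cause.

With only one change at this position, the compounds shown leave open whether the loss is particular to methoxy or would follow from any group placed there. A methyl group, a chlorine atom or an amine at the same carbon could separate these possibilities, and the same methoxy on another carbon of this ring would show whether the sensitivity is confined to the place next to the ring nitrogen.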